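The compounds below may be only part of what the source reports. "The series", "measured", "known", "first", "only" and "open" are said of these compounds alone.

Four compounds share one core and were examined in an assay on LX2 cells for inhibition of COL1A1 promoter (Homo sapiens), read by a luciferase reporter, with a stated time of 24 h, tested at 20 uM; a lower number here means a weaker effect, a higher number a stronger effect of the compound at the concentration tested. Compound 1, `CN(C)c1ccc2c(=O)c(C(=O)Nc3cc(F)cc(F)c3)cn(-c3ccc(OCCCCCCC[N+]45CCN(CC4)CC5)cc3Cl)c2n1`, gives 40.1% in this assay, while compound 2, `CN(C)c1ccc2c(=O)c(C(=O)Nc3cc(F)cc(F)c3)cn(-c3ccc(OCCCCCCC[N+]45CCN(CC4)CC5)cc3F)c2n1`, gives 9.02%. The change between them, (fluoro in place of chloro on an aromatic carbon), made a step of a number 31.1 percentage points lower from compound 1 to compound 2 (beyond the scatter). Compound 3, `CC[N+]1(CCCCCCCOc2ccc(-n3cc(C(=O)Nc4cc(F)cc(F)c4)c(=O)c4ccc(N(C)C)nc43)c(Cl)c2)CCCCC1`, differs from compound 1 in another place, (a group of 8 heavy atoms (7 carbon, 1 nitrogen; one six-membered non-aromatic ring with 1 hetero atom) in place of a group of 8 heavy atoms (6 carbon, 2 nitrogen; 2 six-membered non-aromatic rings with 2 hetero atoms each), on a saturated chain carbon, seven bonds along the chain from an oxygen on an aromatic ring), and in this assay compound 3 is reported as "not active" (no number reported). Compound 4, `CC[N+]1(CCCCCCCOc2ccc(-n3cc(C(=O)Nc4cc(F)cc(F)c4)c(=O)c4ccc(N(C)C)nc43)c(F)c2)CCCCC1`, carries the same change relative to compound 3 as compound 2 does relative to compound 1, namely (fluoro in place of chloro on an aromatic carbon), at the same place. Going by the values given here, because compound 3 already shows "not active" (no number reported), and because the one measured step of this kind was a number 31.1 percentage points lower from compound 1 to compound 2 (beyond the scatter), little room remains for a further drop. Compound 4 is expected to give about 3%, estimated to lie between -10% and 18%.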

Compound 4, a percentage reported as inhibition, at one concentration (the size of the read-out at that concentration, not a potency): "not active" (no number reported)
Compound 4: no number reported, and the estimate cannot be compared.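

Neither compound 3 nor compound 4 has a number in this assay so no step can be read between them. As far as these compounds go, what fluoro in place of chloro does in this pair stays open, and no evidence bears on the result.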